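Cyclohexyl for 4-chlorophenyl on the ring amide nitrogen

The compounds below may be only part of what the source reports. "The series", "measured", "known", "first", "only" and "open" are said of these compounds alone.

Measured compounds in a functional assay on A-375 cells (Homo sapiens) for antiproliferative activity, read by MTT assay, with a stated time of 72 h; a higher number here means a weaker inhibitor, a lower number a stronger inhibitor:
compound 1, `COc1ccc(N2C(=O)COc3ccc(-c4cnc5ccccc5c4)cc32)cc1`: > 40000 nM, a limit of the assay.
compound 2, `O=C1COc2ccc(-c3cnc(Cl)c(NS(=O)(=O)c4ccc(F)cc4)c3)cc2N1c1ccc(F)cc1`: > 40000 nM, a limit of the assay.
compound 3, `O=C1COc2ccc(-c3cccc(NS(=O)(=O)c4ccc(F)cc4)c3)cc2N1c1ccc(Cl)cc1`: 32500 nM.

Within the data shown here, compound 3 carries the only actual number in this assay; the other two entries are limits, as summarised in the limit of > 40000 nM in this assay, at which 2 of the 3 values shown sit. No pair among the measured compounds differs in a single place, so no measured step is available, and nothing in the data explains why compound 3 alone yields a number.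

Compound 4, `O=C1COc2ccc(-c3cccc(NS(=O)(=O)c4ccc(F)cc4)c3)cc2N1C1CCCCC1`, is not yet measured. It differs from compound 3 in one place: cyclohexyl in place of 4-chlorophenyl on an amide-type nitrogen in a ring. With no measured step of this kind in the series, the size and direction of the change cannot be read from the data, so the expectation is a step of no more than the usual scatter in either direction, a 1.1-fold higher number from compound 3 to compound 4 (0.03 log units; within the scatter). Compound 4 is therefore expected to give about 35000 nM, with a plausible range from 10000 nM to 120000 nM, and a fair chance that the assay reports only a limit.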

Compound 4, half-maximal inhibitory concentration: 23800 nM
For compound 4 the middle estimate is 1.5-fold (0.17 log units) above the measured one, within the range that was stated.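

In this assay, cyclohexyl in place of 4-chlorophenyl on the amide-type nitrogen in a ring gives a 1.4-fold lower number from compound 3 to compound 4 (0.14 log units; within the scatter). Among these compounds, this is the first measured step at this position, and it shows that a six-membered aromatic ring of carbon only on this nitrogen is not needed for an actual number, as a six-membered non-aromatic ring of carbon only also yields one. Even so, the series remains close to the end of the measurable range: the limit of > 40000 nM in this assay, at which 2 of the 4 values shown sit.

Still open, as far as these compounds go, is how a methyl, a longer alkyl chain, or a chain ending in an amine or a carboxylic acid on this nitrogen would read in this assay. Neither compound 1 nor compound 2 differs from compound 3 or compound 4 in one place, so their limits remain unconnected to this step.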